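This account rests on a few compounds, and the source may have more. Where it says the series, first, only, none or still open, it means among the compounds named here.

Series notes: the shared core of compound 2 `O=C(NCc1ccc(CNS(=O)(=O)c2ccccc2)cc1)c1cccnc1` carries a (pyridin-3-yl)carbonyl on the amide nitrogen and an unsubstituted phenyl on the sulfonamide. Among the measured compounds shown here, in an assay on MDA-MB-231 cells for binding affinity to C-X-C chemokine receptor type 4 (Homo sapiens), read by immunofluorescence and microscopy, with stated times of 10 min and 30 min (on this read-out lower numbers stand for an effect already at smaller amounts and higher numbers for an effect only at larger amounts of compound), compound 2 gives 10 nM, the lowest of the three numbers measured so far. Compound 1 `COc1ccc(C(=O)NCc2ccc(CNS(=O)(=O)c3ccc(C)cc3)cc2)cc1` has a 4-methoxyphenyl on the carbonyl and a methyl on the sulfonyl aryl; in this assay compound 1 gives 100 nM. Compound 3 `Cc1ccc(S(=O)(=O)NCc2ccc(CNC(=O)c3cccc(C)c3)cc2)cc1` swaps that 4-methoxyphenyl for a 3-methylphenyl; in this assay compound 3 gives 1000 nM. For the measured compounds named here, the one single-point step measured is a 10-fold higher number from compound 1 to compound 3 (1.00 log units; beyond the scatter), so exchanging a methoxyphenyl for a methylphenyl on the carbonyl carbon made the number worse by a clear margin.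

Compound 4 `Cc1ccccc1C(=O)NCc1ccc(CNS(=O)(=O)c2ccccc2)cc1` is not yet measured. Relative to compound 2 the change is 2-methylphenyl in place of pyridin-3-yl on a carbonyl carbon. Going by the values given here, no measured step covers a pyridin-3-yl to methylphenyl exchange directly; the closest guide is the 1>3 step, where a methylphenyl on the carbonyl gave the highest number of the set, and the nitrogen-free aryl is expected to cost in the same direction here. The step of a 10-fold higher number from compound 2 to compound 4 (1.00 log units; beyond the scatter) is therefore expected to be beyond the scatter, toward higher numbers. For compound 4 in this assay the estimate is 100 nM, within 20 nM to 600 nM.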

Compound 4, effective concentration (reported as EC, without a stated level of effect): 1 nM
Beside the measured number, compound 4's estimate is 100-fold (2.00 log units) above it, and the stated range ends above it.
By their numbers in this assay, from the lowest: compound 4; then compound 2; then compound 1; then compound 3.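

In this assay, a 10-fold lower number from compound 2 to compound 4 (1.00 log units; beyond the scatter) shows that, with the unsubstituted phenyl on the sulfonamide held fixed, the pyridin-3-yl on the carbonyl carbon is not required for a low number: an all-carbon aromatic ring, the 2-methylphenyl, serves at least as well at this place. A methylphenyl on this carbonyl carbon is therefore not unfavourable as such, even though a 10-fold higher number from compound 1 to compound 3 (1.00 log units; beyond the scatter) pointed the other way; that earlier pair has a different leaving group, a 3-methylphenyl rather than a 2-methylphenyl, and a methyl on the sulfonyl aryl, so the two steps do not describe the same change. Nothing at hand gives a reason for the drop in the number at this place.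

Among the compounds shown here, the single pair cannot separate the loss of the ring nitrogen from the arrival of the methyl group, and an unsubstituted phenyl on the carbonyl carbon would divide the two. How much the methyl itself contributes would also need a chlorine or a longer alkyl chain in its place, and a primary amine or a carboxylic acid on that ring remains an open question too.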